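This account rests on a few compounds, and the source may have more. Where it says the series, first, only, none or still open, it means among the compounds named here.

Measured compounds in an ADME assay on J774.A1 cells (Mus musculus) for cytotoxicity, read by MTT assay, with a stated time of 72 h; a lower number here means that less compound is tolerated, a higher number that more compound is tolerated:
compound 1 `CCC1(c2ccccc2OC)CC(S(=O)(=O)c2ccc(F)cc2)=C(c2ccc(/C(N)=N\O)cc2)O1`, 9880 nM
compound 2 `CC1(c2ccc(Br)cc2)CC(S(=O)(=O)c2ccc(F)cc2)=C(c2ccc(/C(N)=N\O)cc2)O1`, 10500 nM
compound 3 `CC1(Cc2ccccc2)CC(S(=O)(=O)c2c(F)cccc2F)=C(c2ccc(/C(N)=N\O)cc2)O1`, 27000 nM

Compound 2 stands second highest of the three numbers in this assay. Its nearest neighbour is compound 1, whose number lies lower by an amount within the usual scatter, so no order between compound 2 and compound 1 can be read from these two values. Compound 3 gives the highest number of the three, and its gap to compound 2 lies beyond the scatter. Within the data shown here, no two measured compounds differ in only one place, so no single-change step is available from the measured set.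

Compound 4 `COc1cc(-c2ccc(C3(C)CC(S(=O)(=O)c4ccc(F)cc4)=C(c4ccc(/C(N)=N\O)cc4)O3)cc2)cc(OC)c1OC` has not yet been measured in this assay. It differs from compound 2 in one place: 3,4,5-trimethoxyphenyl in place of bromo on an aromatic carbon. The new group sits on an aromatic carbon of a six-membered aromatic ring of carbon only, para to a large group. Among the measured compounds shown here, nothing among the measured compounds isolates the effect of such a change, and the three measured values span only a modest range. The step from compound 2 is expected to be a 1.2-fold lower number from compound 2 to compound 4 (0.07 log units; within the scatter), not beyond the scatter in either direction. For compound 4 the expected value in this assay is 9000 nM, with a range from 3500 nM to 23000 nM.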

Compound 4, half-maximal cytotoxic concentration: 5220 nM
For compound 4 the middle estimate is 1.7-fold (0.24 log units) above the measured one; low and high end bracket the measured number.
By their numbers in this assay, from the lowest: compounds 4, 1 and 2 (each within the scatter of the next); then compound 3.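

In this assay, exchanging bromo for 3,4,5-trimethoxyphenyl gives a 2.0-fold lower number from compound 2 to compound 4 (0.30 log units; within the scatter). Among these compounds, this is the first single-change step, and it concerns an aromatic carbon para to a large group. At this position, going from bromo to 3,4,5-trimethoxyphenyl, with one six-membered aromatic ring and 3 hydrogen-bond acceptors added, does not move the number beyond the scatter. No measurement at hand explains this reading.

This single step does not separate the contributions of the added ring and its three methoxy groups; a plain phenyl at the same carbon would bear on that. Going by these compounds, how an amine or a carboxylic acid on this aromatic carbon would read in this assay remains open.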